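This account rests on a few compounds, and the source may have more. Where it says the series, first, only, none or still open, it means among the compounds named here.

Compound 3 `COc1c(Br)cc(Br)cc1C(=O)Nc1ccc(Sc2nc3ccccc3s2)c(Cl)c1` stands at the ceiling of the numbers shown so far: in an assay for inhibition of HSP60/HSP10 (Homo sapiens), with a stated time of 60 min (on this read-out higher numbers stand for weaker inhibition and lower numbers for stronger inhibition), compound 3 gives > 100000 nM, which is a limit of the assay and not a number. Compound 2 `COc1ccccc1C(=O)Nc1ccc(Sc2nc3ccccc3s2)cc1` likewise gives only a limit in this assay, > 100000 nM. For the measured compounds named here, compound 1 `O=C(Nc1ccc(Sc2nc3ccccc3s2)c(Cl)c1)c1cccc(Br)c1O` is the one member with a measured number and gives 6900 nM in this assay.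

Going by the values given here, the only measured step that alters the group on the carbonyl carbon is an at least 14-fold higher number from compound 1 to compound 3 (1.16 log units; beyond the scatter), and since it ends at a limit its true size is open; the limit of > 100000 nM in this assay, at which 2 of the 3 values shown sit, caps what can be read from it.

The change to compound 4 `COc1ccccc1C(=O)Nc1ccc(Sc2nc3ccccc3s2)c(Cl)c1` is a group of 8 heavy atoms (7 carbon, 1 oxygen; one six-membered aromatic ring of carbon only) in place of a group of 10 heavy atoms (7 carbon, 1 oxygen, 2 bromine; one six-membered aromatic ring of carbon only), on a carbonyl carbon. Among the compounds with values here, no measured step covers this change directly. The 2-methoxyphenyl group that enters is the same group carried by compound 2, which differs from compound 4 in one further place, so the weight of what is seen points to compound 4 staying at the limit as well, though the removal of two bromines could open some room for a measurable number.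

For compound 4 the expected value in this assay is 100000 nM, within 30000 nM to 300000 nM. The step from compound 3 to compound 4 is therefore expected to be a number no higher from compound 3 to compound 4 (the limit leaves the size open), none beyond the scatter.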

Compound 4, half-maximal inhibitory concentration: > 100000 nM
Compound 4: a limit, no number (the forecaster's own chance of this, stated with the estimate: 70%); the middle value lies on the limit itself.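

In this assay, 2-methoxyphenyl in place of 3-bromo-2-hydroxyphenyl on the carbonyl carbon gives an at least 14-fold higher number from compound 1 to compound 4 (1.16 log units; beyond the scatter), with the true size left open, and the chloro of compound 1 is kept in this comparison. The earlier step to compound 3 came with bromines on the entering group, whereas compound 4 carries none on that group and still reaches only a limit, so the loss of a measured number in this pair does not depend on those bromines. The steps to compound 4 from compound 3 and from compound 2 join two limits and cannot be read, so neither the bromines nor the chloro can be given a size here: the limit of > 100000 nM in this assay, at which 3 of the 4 values shown sit.

The compounds shown do not separate the hydroxy from the bromo of the 3-bromo-2-hydroxyphenyl group, so it stays open whether the measured number of compound 1 needs both. A plain 2-hydroxyphenyl or a 3-bromo-2-methoxyphenyl on the carbonyl carbon would divide the change, and a 3-bromo-2-aminophenyl would test whether the hydroxy can be replaced.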